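The source may hold more compounds than are shown below. What is called first, only, known or untested is meant among the compounds shown, and "the series" means these compounds.

Compound 2 `N#CC1=C(N)N(c2ccc(S(N)(=O)=O)cc2)C2=C(C(=O)CCC2)C1c1cccc([N+](=O)[O-])c1` gives 73% in a functional assay on Ehrlich cells (Mus musculus) for antiproliferative activity, read by trypan blue exclusion, with a stated time of 2 h, tested at 50 ug/mL (a lower number here means a weaker effect, a higher number a stronger effect of the compound at the concentration tested), the highest of the two numbers shown so far; its nearest neighbour is compound 1 `Cc1ccc(C2C(C#N)=C(N)N(c3ccc(S(N)(=O)=O)cc3)C3=C2C(=O)CCC3)cc1`, which in this assay gives 50%. Among the measured compounds shown here, the only measured step, a number 23 percentage points higher from compound 1 to compound 2 (beyond the scatter), joins these two compounds. Compound 3 `N#CC1=C(N)N(c2ccc(S(N)(=O)=O)cc2)C2=C(C(=O)CCC2)C1c1ccc([N+](=O)[O-])cc1` has not yet been measured. Its change from compound 2 is 4-nitrophenyl in place of 3-nitrophenyl on a saturated ring carbon. For the measured compounds named here, no measured step moves a nitro group from one position to another on that ring; the one step at hand, a number 23 percentage points higher from compound 1 to compound 2 (beyond the scatter), shows that 3-nitrophenyl in place of 4-methylphenyl brought a modest rise, but it carries no information on where the nitro group sits. For compound 3 the expectation is therefore no step beyond the scatter, an estimated a number 5 percentage points lower from compound 2 to compound 3 (within the scatter). The estimated value for compound 3 in this assay is 68%, with a range from 50% to 85%.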

Compound 3, a percentage reported as activity, at one concentration (the size of the read-out at that concentration, not a potency): 95%
Compound 3: middle estimate off by 27 percentage points, on the low side, and the stated range ends below it.
By their numbers in this assay, from the lowest: compound 1; then compound 2; then compound 3.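

In this assay, the place of the nitro group on the phenyl ring proves to matter: with the same atoms joined differently, 4-nitrophenyl in place of 3-nitrophenyl on the saturated ring carbon gives a number 22 percentage points higher from compound 2 to compound 3 (beyond the scatter). Between 4-methylphenyl and 4-nitrophenyl, nitro in place of methyl on an aromatic carbon gives a number 45 percentage points higher from compound 1 to compound 3 (beyond the scatter) and so shows that the group itself also counts, leaving compound 3 highest of the three, with its steps to both others beyond the scatter. No independent measurement accounts for either step. Still open, from the compounds shown here alone, is how other groups would fare on that phenyl ring, such as an amine or a carboxylic acid. Each number is also a read-out at one concentration, so it tells of a stronger or weaker effect at that concentration only.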